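Fluoro to trifluoromethyl at the solubility limit

This account rests on a few compounds, and the source may have more. Where it says the series, first, only, none or still open, it means among the compounds named here.

In a physicochemical assay for solubility, using the shake flask method, in simulated intestinal fluid, measured as kinetic solubility, with a stated time of 2 h, at 25 degrees C, at pH 6.5 (on this read-out lower numbers stand for lower solubility and higher numbers for higher solubility), compound 3 `Cc1noc(-c2nc(C)c3c(c2N)C(=O)N(Cc2cccc(F)c2)C3=O)n1` stands at < 5000 nM, a limit and not a number. Compound 1 `Cc1noc(-c2nc(C)c3c(c2N)C(=O)N(Cc2ccc(F)cc2)C3=O)n1` gives < 5000 nM, also a limit. Compound 2 `Cc1noc(-c2nc(C)c3c(c2N)C(=O)N(CC2CCNCC2)C3=O)n1` reaches 160000 nM. Compound 4 `Cc1noc(-c2nc(C)c3c(c2N)C(=O)N(Cc2cccc(C(F)(F)F)c2)C3=O)n1` differs from compound 3 by trifluoromethyl in place of fluoro on an aromatic carbon, with trifluoromethyl in place of fluoro on an aromatic carbon. The closest measured change is a step that the two limits leave unreadable from compound 1 to compound 3. The other two are an at least 32-fold higher number from compound 1 to compound 2 (1.50 log units; beyond the scatter) and an at least 32-fold lower number from compound 2 to compound 3 (1.50 log units; beyond the scatter), but both exchange piperidin-4-yl and a fluorophenyl group, so they do not test this change. Both fluorophenyl compounds sit at the limit of < 5000 nM in this assay, at which 2 of the 3 values shown sit, so no shift beyond the scatter is expected. The expected change is a step that the limit leaves unreadable from compound 3 to compound 4. Compound 4 is estimated at 3000 nM, within an expected range from 800 nM to 6000 nM.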

Compound 4, solubility: < 5000 nM
Compound 4 ended at the assay's limit (the forecaster's own chance of this, stated with the estimate: 85%); the middle value is on the limit's open side.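

Trifluoromethyl in place of fluoro leaves compound 4 in this assay at the same limit as compound 3, so the steps among the three compounds with a substituted phenyl group cannot be read: the limit of < 5000 nM in this assay, at which 3 of the 4 values shown sit.

A real difference between fluoro and trifluoromethyl at this position could therefore stay hidden. The 3-(trifluoromethyl)phenyl group in place of piperidin-4-yl gives an at least 32-fold lower number from compound 2 to compound 4 (1.50 log units; beyond the scatter), so the wide gap seen with both fluorophenyl groups also holds for this one.

On these data alone, how far under the limit these compounds lie remains unknown. Also open, as far as these compounds go, is whether an amine or a carboxylic acid on the aromatic ring would bring a value that can be read.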